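The compounds below may be only part of what the source reports. "The series", "measured", "known", "first", "only" and "open" are said of these compounds alone.

Measured so far:
- compound 1, `CN1CC2C=C(c3cncc(C#N)c3)CC(C2)C1`: 24 nM
- compound 2, `Clc1ccccc1Oc1cncc(C2=CC3CNCC(C2)C3)c1`: 0.9 nM

For the measured compounds named here, in an in vitro assay on SH-EP1 cells for displacement of a labelled ligand from Neuronal acetylcholine receptor; alpha4/beta2 (Homo sapiens) (a lower number here means a stronger inhibitor, a higher number a weaker inhibitor), compound 2 gives 0.9 nM, the lowest of the two numbers so far. Its nearest neighbour is compound 1, which in this assay gives 24 nM; the two structures differ in more than one place, so only the two values themselves are compared here, and the gap between them lies beyond the scatter.

Compound 3, `COc1cncc(C2=CC3CNCC(C2)C3)c1`, has not yet been measured. It differs from compound 2 by methyl in place of 2-chlorophenyl on an oxygen on an aromatic ring. Going by the values given here, no measured pair shows this change by itself, so its effect is uncertain. The expectation is that compound 3 loses potency relative to compound 2, with an estimated step of a 5.6-fold higher number from compound 2 to compound 3 (0.74 log units; beyond the scatter) in this assay, beyond the scatter but probably not reaching the value of compound 1. The estimate for compound 3 in this assay is 5 nM, with a range from 1 nM to 25 nM.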

Compound 3, inhibition constant: 0.3 nM
Compound 3: middle estimate off by 17-fold (1.22 log units), on the high side; the whole stated range lies above it.
By their numbers in this assay, from the lowest: compound 3; then compound 2; then compound 1.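

On this oxygen on an aromatic ring, the 2-chlorophenyl group is not required for potency in this assay: methyl in its place gives a 3.0-fold lower number from compound 2 to compound 3 (0.48 log units; beyond the scatter), a modest change in favour of the much smaller group. Compound 1 and compound 2 differ in more than one place and could say nothing about this position alone, whereas this single change shows that a group with no ring keeps the potency of the series and improves on it. Nothing available here accounts for the step.

This one pair cannot separate the effect of losing the aromatic ring from the effect of losing the chlorine. Also open, from the compounds shown here alone, is how a longer chain such as butyl, or an unsubstituted phenyl, on the same oxygen would read in this assay, and whether the trend from 2-chlorophenyl to methyl would hold across such groups.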